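Bromo to Nitro on the Dimethoxyphenol Core

This account rests on a few compounds, and the source may have more. Where it says the series, first, only, none or still open, it means among the compounds named here.

Two measured compounds frame this account. Compound 1 `COc1cc(CCc2ccc(Br)cc2)cc(OC)c1O` carries a bromo group and, in a functional assay on MKN-45 cells (Homo sapiens) for antiproliferative activity, read by MTT assay, with a stated time of 72 h (a lower number here means a stronger inhibitor, a higher number a weaker inhibitor), compound 1 gives 1490 nM, the lowest of the two numbers recorded. Compound 2 `COc1ccc(CCc2ccc([N+](=O)[O-])cc2)cc1OC`, which bears a nitro group on a different substitution pattern of the shared core, gives 13700 nM in this assay, a gap from compound 1 that lies well beyond the usual scatter. Compound 3 `COc1cc(CCc2ccc([N+](=O)[O-])cc2)cc(OC)c1O` keeps the core of compound 1 but differs from it in one place: nitro in place of bromo on an aromatic carbon. For the measured compounds named here, no measured pair shows this exact step, so its size is uncertain; the weak result of compound 2 offers only indirect guidance, because its core also differs. A modest loss of potency in this assay seems more likely than a gain, and the step of a 2.3-fold higher number from compound 1 to compound 3 (0.37 log units; beyond the scatter) reflects that expectation. Compound 3 is therefore estimated at 3500 nM, within a range of 1200 nM to 10000 nM.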

Compound 3, half-maximal inhibitory concentration: 15400 nM
Estimate against measurement, compound 3: 4.4-fold (0.64 log units) below, outside the stated range (above it).
By their numbers in this assay, from the lowest: compound 1; then compounds 2 and 3 (each within the scatter of the next).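

In this assay the change from bromo to nitro, on an aromatic carbon para to a large group, amounts to a 10-fold higher number from compound 1 to compound 3 (1.01 log units; beyond the scatter) on an otherwise unchanged core, a large step. For the compounds shown here, this is the first direct reading of the position: the earlier pair differed in more than one place, whereas here the loss of potency can be assigned to this single exchange. Nothing measured here explains the size of the step.

The compounds shown leave open how an amine, a carboxylic acid or a chloro group at this position would compare with bromo on the same core. Going by these compounds alone, with only two groups read here, they also cannot tell whether bromo is unusually favourable or nitro unusually poor.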